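The source may report more compounds than this note shows. Statements on the series, on what has been measured and on what is new or still open speak of the compounds shown alone.

Measured compounds:
- compound 1 `Cc1cc(COc2ccccc2)nc(-c2ccccn2)n1`: 794 nM
- compound 2 `Cc1cc(COc2cccc(C#N)c2)nc(-c2ccccn2)n1`: 2510 nM
- compound 3 `Cc1cc(COc2ccc(C#N)cc2)nc(-c2ccccn2)n1`: 31600 nM

Compound 1 carries the unsubstituted phenyl ether and gives the lowest number of the three in a functional assay on cells for antagonist activity at Free fatty acid receptor 1 (Homo sapiens), read by TR-FRET and inositol phosphate accumulation, with a stated time of 2 h; a lower number here means a stronger inhibitor, a higher number a weaker inhibitor. The two cyano analogues both give higher numbers: a 3.2-fold higher number from compound 1 to compound 2 (0.50 log units; beyond the scatter) and a 40-fold higher number from compound 1 to compound 3 (1.60 log units; beyond the scatter), so each substitution on that aromatic ring measured so far has weakened the inhibition, to a modest or to a large degree.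

Compound 4 `Cc1cc(COc2ccccc2F)nc(-c2ccccn2)n1` is not yet measured. It differs from compound 1 in one place: fluoro in place of hydrogen on an aromatic carbon. Neither cyano step is the same change; both replace hydrogen with a nitrile, whereas here a single fluorine enters, ortho to a large group, with no new donor or acceptor. The cyano steps bear on the question only in that substitution of this ring has so far cost potency in this assay. A step from compound 1 to compound 4 is therefore expected to be small, towards a higher number if anything, and it may well stay within the scatter: a 1.5-fold higher number from compound 1 to compound 4 (0.18 log units; within the scatter). On that basis compound 4 is estimated at 1200 nM in this assay, with a likely range from 400 nM to 4000 nM.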

Compound 4, half-maximal inhibitory concentration: 398 nM
Compound 4: the middle estimate sits 3.0-fold (0.48 log units) above what was measured; the measured number lies below the stated range.
By their numbers in this assay, from the lowest: compounds 4 and 1 (each within the scatter of the next); then compound 2; then compound 3.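

In this assay, for the compounds shown here, fluoro in place of hydrogen on an aromatic carbon gives a 2.0-fold lower number from compound 1 to compound 4 (0.30 log units; within the scatter) and is the first substitution on this phenyl ring whose step stays inside the scatter. The ring therefore accepts a fluoro ortho to a large group while remaining within the scatter of the unsubstituted compound 1, and compound 4 goes against the earlier reading, drawn from compounds 2 and 3 alone, that any substitution on this ring weakens inhibition. Both the group and its place on the ring differ between the fluoro step and the two cyano steps, so these steps do not separate an effect of the group from an effect of its place, and no measurement offered alongside the series explains the contrast.

Still open, on these data alone, is whether this place accepts only a single fluoro or also larger groups such as chloro, methyl, methoxy or trifluoromethyl, and whether an amine or a carboxylic acid there would move the number beyond the scatter. Also open, as far as these compounds go, is how fluoro behaves at the two places that carry the nitrile in compounds 2 and 3, which would show whether those steps follow the place or the nitrile itself.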